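Cytotoxicity notes on a pyridinylmethylene piperidinone series

This account rests on a few compounds, and the source may have more. Where it says the series, first, only, none or still open, it means among the compounds named here.

Compound 2 `CN1C/C(=C\c2ccncc2)C(=O)/C(=C/c2ccccc2C(F)(F)F)C1` and compound 1 `CN1C/C(=C\c2ccncc2)C(=O)/C(=C/c2ccccc2F)C1` share one core and differ by a single group: fluoro in place of trifluoromethyl on an aromatic carbon. In an ADME assay on L02 cells (Homo sapiens) for cytotoxicity, read by MTT assay, with a stated time of 24 h (a higher number here means a weaker inhibitor, a lower number a stronger inhibitor), compound 2 gives 15800 nM, and compound 1 gives 14900 nM; the step of a 1.1-fold lower number from compound 2 to compound 1 (0.03 log units; within the scatter) is within the scatter, so the two read as equal.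

Compound 3 `O=C1/C(=C/c2cccnc2)CN(S(=O)(=O)c2ccc(C(F)(F)F)cc2)C/C1=C\c1ccccc1F` carries a different core; how it differs from compound 2 is not broken down here. In this assay compound 3 gives 11300 nM, which lies within the scatter of both compound 1 and compound 2, so no order among the three can be stated.

Compound 4 `O=C1/C(=C/c2cccnc2)CN(S(=O)(=O)c2ccc(F)cc2)C/C1=C\c1ccccc1F`, not yet measured, differs from compound 3 by fluoro in place of trifluoromethyl on an aromatic carbon. Going by the values given here, this is the same kind of change as the one from compound 2 to compound 1, but the place is not the same: there the fluoro stood ortho to a large group, here it stands para to a large group, and it sits on a different core. Among the compounds with values here, the only measured instance of this change, from compound 2 to compound 1, moved the number by an amount within the scatter, so a step of similar size, a 1.0-fold higher number from compound 3 to compound 4 (0.01 log units; within the scatter), is expected from compound 3 to compound 4. On that basis compound 4 is estimated to give 11500 nM in this assay, with a range from 7000 nM to 19000 nM.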

Compound 4, half-maximal inhibitory concentration: 15600 nM
Estimate against measurement, compound 4: 1.4-fold (0.13 log units) below, and the stated range covers the measured number.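

In this assay, fluoro in place of trifluoromethyl on an aromatic carbon gives a 1.4-fold higher number from compound 3 to compound 4 (0.14 log units; within the scatter), so on the core of compound 3 the two groups read as equal, as they do on the core of compound 1. Set side by side, the two instances of the change do not differ: the same change on two cores in this assay, a 1.1-fold lower number (0.03 log units; within the scatter) from compound 2 to compound 1 and a 1.4-fold higher number (0.14 log units; within the scatter) from compound 3 to compound 4, 1.5-fold (0.17 log units) apart, within the scatter of two such steps. This shows that the change carried over between these two cores without a step beyond the scatter in this one cytotoxicity read-out, but two instances that each stay within the scatter do not show that it would do so on a further core, and they do not separate the role of the core from that of the place on the aromatic ring.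

The compounds shown leave open whether an amine or a carboxylic acid on the same aromatic carbon, in place of the fluoro of compound 4, would give a step beyond the scatter. Also open, on these data alone, is whether a hydroxyl or a methoxy group there would read differently on the core of compound 1 than on the core of compound 3.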